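The source may hold more compounds than are shown below. What is called first, only, known or untested is meant among the compounds shown, and "the series" means these compounds.

Compound 2, with the structure `Cc1c(C(C)C)c(=O)on1C(=O)N1CCCCC1`, is one of three closely related compounds tested in an assay (strain Wistar) for inhibition of Hormone-sensitive lipase (Rattus norvegicus), read by spectrophotometry (a higher number here means a weaker inhibitor, a lower number a stronger inhibitor), where compound 2 gives 2 nM. Compound 1, with the structure `Cc1c(C)n(C(=O)N2CCCCC2)oc1=O`, gives 13 nM in this assay, and compound 3, with the structure `Cc1c(C2CCSCC2)c(=O)on1C(=O)N1CCCCC1`, gives 11 nM. On these numbers compound 2 stands lowest: the step of a 6.5-fold lower number from compound 1 to compound 2 (0.81 log units; beyond the scatter) and the step of a 5.5-fold higher number from compound 2 to compound 3 (0.74 log units; beyond the scatter) both set it apart from the other two, whereas the step of a 1.2-fold lower number from compound 1 to compound 3 (0.07 log units; within the scatter) leaves compound 1 and compound 3 indistinguishable.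

Compound 4, with the structure `Cc1c(C(C)C)c(=O)on1C(=O)N1CCCCC1C`, differs from compound 2 by a single change, (methyl in place of hydrogen on a saturated ring carbon). All three measured steps change the group on the aromatic carbon, and none touches the saturated six-membered ring that is altered here, so they bear on this step only in showing that small changes in this series have shifted the number by modest amounts at most. Among the compounds with values here, with no direct precedent for this position, the expectation for compound 4 in this assay is a step of a 1.5-fold higher number from compound 2 to compound 4 (0.18 log units; within the scatter), that is, no change beyond the scatter. Compound 4 is therefore estimated at 3 nM, within a range from 1 nM to 12 nM.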

Compound 4, half-maximal inhibitory concentration: 93 nM
Compound 4: middle estimate off by 31-fold (1.49 log units), on the low side, outside the stated range (above it).
By their numbers in this assay, from the lowest: compound 2; then compounds 3 and 1 (each within the scatter of the next); then compound 4.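

The earlier steps shown here all changed the group on the aromatic carbon, and in this assay none of them moved the number as far as this one does: a methyl in place of hydrogen on a saturated ring carbon, next to the ring nitrogen, gives a 47-fold higher number from compound 2 to compound 4 (1.67 log units; beyond the scatter). The six-membered ring is therefore far from a passive part of these molecules, since adding 1 heavy atom here costs more than replacing isopropyl with the much larger thian-4-yl, which gives a 5.5-fold higher number from compound 2 to compound 3 (0.74 log units; beyond the scatter). Nothing available gives a reason for the size of this step.

As far as these compounds go, whether an ethyl or a hydroxyl group on this same carbon would give a step of similar size remains open, as does the effect of a methyl on a different carbon of the ring. From the compounds shown here alone, it is also open whether the same methyl would weaken inhibition as strongly in compound 1 or compound 3, which carry methyl and thian-4-yl on the aromatic carbon in place of isopropyl.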